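Ester for Amide on an Oxazole Ketone Inhibitor

The compounds below may be only part of what the source reports. "The series", "measured", "known", "first", "only" and "open" are said of these compounds alone.

Measured so far:
compound 1, `CNC(=O)c1cnc(C(=O)CCc2ccc(COc3ccccc3)cc2)o1`: 3.6 nM
compound 2, `COC(=O)c1cccc(-c2cnc(C(=O)CCc3ccc(-c4ccc(CN5CCCC5)cc4)cc3)o2)n1`: 18 nM

In an assay for inhibition of Fatty-acid amide hydrolase 1 (Rattus norvegicus) (on this read-out higher numbers stand for weaker inhibition and lower numbers for stronger inhibition), compound 1 gives 3.6 nM, the lowest of the two numbers shown. Compound 2 gives 18 nM, a higher number that lies beyond the usual scatter. Compound 3, `COC(=O)c1cnc(C(=O)CCc2ccc(COc3ccccc3)cc2)o1`, differs from compound 1 in one place: methoxy in place of methylamino on a carbonyl carbon. Within the data shown here, no measured pair shows this change, so its effect has to be guessed. The step of a 1.7-fold higher number from compound 1 to compound 3 (0.22 log units; within the scatter) is expected to be a small loss, close to the scatter. Compound 3 is therefore estimated at 6 nM, within a range from 1.5 nM to 25 nM.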

Compound 3, inhibition constant: 1.6 nM
The estimate for compound 3 lay 3.8-fold (0.57 log units) above the measured number, and the stated range covers the measured number.
By their numbers in this assay, from the lowest: compound 3; then compound 1; then compound 2.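

On this carbonyl carbon, methoxy in place of methylamino gives a 2.3-fold lower number from compound 1 to compound 3 (0.35 log units; beyond the scatter) in this assay. The step is modest but beyond the scatter, so the hydrogen-bond donor of the methylamino group is not required for strong inhibition at this place. No supporting measurement accounts for the gain. The compounds shown leave open how a carboxylic acid, an ethoxy group or a dimethylamino group on the same carbonyl carbon would compare. They also leave open whether this change gives a similar step on a core other than that of compound 1.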